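The source may report more compounds than this note shows. Statements on the series, on what has been measured and on what is new or still open speak of the compounds shown alone.

Measured so far:
Compound 1, `COc1cc(OC)cc(-c2cc3ccccc3c(-c3cccc(O)c3)n2)c1`, 3870 nM
Compound 2, `COc1cc(OC)cc(-c2cc3ccccc3c(-c3cccc(OC)c3)n2)c1`, > 50000 nM
Compound 3, `COc1cc(OC)cc(-c2cc3ccccc3c(-c3cccc(N)c3)n2)c1`, 13200 nM

Three compounds share one core and differ only in the group on the pendant phenyl ring. In a functional assay on DU-145 cells (Homo sapiens) for cytotoxicity, read by CCK-8 assay and cell counting, with a stated time of 72 h (on this read-out lower numbers stand for stronger inhibition and higher numbers for weaker inhibition), compound 1 gives 3870 nM. Compound 2 reaches only (the limit of > 50000 nM in this assay, at which 1 of the 3 values shown sits), which is a limit of the assay and not a number. Compound 3 gives 13200 nM, the highest of the two numbers shown; the step of a 3.4-fold higher number from compound 1 to compound 3 (0.53 log units; beyond the scatter) places it beyond the scatter from compound 1, and the step of an at least 3.7-fold lower number from compound 2 to compound 3 (0.57 log units; beyond the scatter) shows only that its number lies under the limit of compound 2.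

Compound 4, `COc1cc(OC)cc(-c2cc3ccc(N(C)C)cc3c(-c3cccc(N)c3)n2)c1`, keeps the amino group of compound 3 and changes the fused ring instead: dimethylamino in place of hydrogen on an aromatic carbon. For the measured compounds named here, none of the measured steps touches this ring, so the steps of an at least 12-fold higher number from compound 1 to compound 2 (1.11 log units; beyond the scatter) and a 3.4-fold higher number from compound 1 to compound 3 (0.53 log units; beyond the scatter) give only a sense of how much the numbers in this assay have moved for a single substitution. Without a direct precedent, compound 4 is expected to stay near compound 3, with a step of a 1.5-fold lower number from compound 3 to compound 4 (0.17 log units; within the scatter) that may well sit within the scatter. Compound 4 is estimated at 9000 nM, in a range from 2500 nM to 35000 nM.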

Compound 4, half-maximal inhibitory concentration: 7330 nM
Estimate against measurement, compound 4: 1.2-fold (0.09 log units) above, and the stated range covers the measured number.
By their numbers in this assay, from the lowest: compounds 1, 4 and 3 (each within the scatter of the next, the first and the last beyond it). At a limit, above all of these: compound 2.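

In this assay, for the compounds shown here, the fused ring of the shared core carries a change for the first time, and the step of a 1.8-fold lower number from compound 3 to compound 4 (0.26 log units; within the scatter) leaves compound 3 and compound 4 indistinguishable in this read-out. This aromatic carbon, on a six-membered aromatic ring of carbon only, therefore takes a dimethylamino group in place of hydrogen with no change that can be read, whereas a single change on the pendant phenyl ring, seen in the step of a 3.4-fold higher number from compound 1 to compound 3 (0.53 log units; beyond the scatter), moves the number beyond the scatter. Nothing in the data shown bears on why the new group leaves the number where it is.

The compounds shown leave open how a carboxylic acid, a morpholine or a longer amine chain would read on this same carbon, and whether a group larger than dimethylamino would still leave the number in place. Also open, from the compounds shown here alone, is whether dimethylamino on the fused ring would give the same result with the hydroxy group of compound 1 on the pendant ring in place of the amino group.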